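Hydroxy in Place of Ethyl: an Untested Neighbour of Compound 2

This account rests on a few compounds, and the source may have more. Where it says the series, first, only, none or still open, it means among the compounds named here.

Three compounds sharing one core have been run in a functional assay on the whole organism (Tail, strain ICR) with Mus musculus as the target, in the tail flick test, with a stated time of 60 min, at a dose of 25 umol/kg by the oral route; on this read-out lower numbers stand for a weaker effect and higher numbers for a stronger effect at the one dose given. Compound 2 `CC[C@H](C)[C@H](NC(=O)CN(c1nc(Cl)nc2[nH]cnc12)C1CC1)C(=O)O` gives 36%. Compound 3 `O=C(OCc1ccccc1)[C@@H]1CCCN1C(=O)CN(c1ncnc2c1ncn2C1CCCCO1)C1CC1` gives 36.7% and compound 1 `O=C(CN(c1ncnc2c1ncn2C1CCCCO1)C1CC1)NCC(=O)OCc1ccccc1` gives 40.4%; both differences from compound 2 fall within the usual scatter, so the three cannot be told apart on these numbers. Compound 4 `C[C@@H](O)[C@H](NC(=O)CN(c1nc(Cl)nc2[nH]cnc12)C1CC1)C(=O)O` has not yet been tested in this assay. It differs from compound 2 in one place: hydroxy in place of ethyl on a saturated chain carbon bound to two saturated chain carbons. For the measured compounds named here, no measured pair shows this change, so there is no guide to its size. The expected step is a number 2 percentage points lower from compound 2 to compound 4 (within the scatter), which means no change beyond the scatter. Compound 4 is therefore expected to give about 34%, with a range from 20% to 50%.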

Compound 4, a percentage reported as activity, at one dose (the size of the read-out at that dose, not a potency): 30.1%
Beside the measured number, compound 4's estimate is 3.9 percentage points above it; the range from low to high includes it.
By their numbers in this assay, from the lowest: compounds 4, 2, 3 and 1 (each within the scatter of the next, the first and the last beyond it).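

Hydroxy in place of ethyl on this saturated chain carbon now has a direct reading: in this assay the step is a number 5.9 percentage points lower from compound 2 to compound 4 (within the scatter) and so cannot be told from the scatter. This position therefore takes the loss of two carbons and the gain of a hydrogen-bond donor and acceptor without a clear change in the read-out. Nothing measured here explains the size of this step.

From the compounds shown here alone, whether an amine or a longer chain at this carbon would move the number beyond the scatter stays open.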